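The compounds below may be only part of what the source reports. "The series", "measured", "known", "first", "only" and "open" are said of these compounds alone.

Of the compounds shown here, three of one series have been tested in a functional assay on FM3A cells (Homo sapiens) for inhibition, with FM3A (Mus musculus) as the target; a higher number here means a weaker inhibitor, a lower number a stronger inhibitor. Compound 2 `CC(O)n1cnc2c(Cl)nc(I)nc21` gives 479000 nM in this assay. Compound 3 `CC(O)n1cnc2c(N)nc(I)nc21`, which carries an amino group in place of the chloro on an aromatic carbon, gives 452000 nM. The step of a 1.1-fold lower number from compound 2 to compound 3 (0.03 log units; within the scatter) is small, and the two numbers stand within the scatter of each other, so neither compound can be called the stronger inhibitor on this evidence. Compound 1 `CC(=O)OC(C)n1cnc2c(Cl)nc(N)nc21` reaches only a limit of the assay, > 500000 nM, with no number behind it, as the limit of > 500000 nM in this assay, at which 1 of the 3 values shown sits, records. Compound 4 `Nc1nc(I)nc2c1ncn2OCCO` has not yet been measured; it differs from compound 3 in one place: 2-hydroxyethoxy in place of 1-hydroxyethyl on an aromatic nitrogen. Among the measured compounds shown here, no measured step touches this position on the ring nitrogen, and the one step that is known was within the scatter, so the expected step of a 1.0-fold lower number from compound 3 to compound 4 (0.00 log units; within the scatter) is no change beyond the scatter. Compound 4 is therefore estimated at 450000 nM, with a range from 200000 nM to 900000 nM, and it could well end at the limit of the assay rather than at a number.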

Compound 4, half-maximal inhibitory concentration: > 500000 nM
Compound 4 was reported as a limit; the forecaster's own chance of this, stated with the estimate: 40%; at least 1.1-fold (0.04 log units) between middle value and limit.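

At the ring nitrogen, the first change read at this position, 2-hydroxyethoxy in place of 1-hydroxyethyl, gives an at least 1.1-fold higher number from compound 3 to compound 4 (0.04 log units; that floor lies within the scatter). The result for compound 4 is a limit rather than a number, so this step is only a floor: it gives no sign of a stronger inhibitor, but its true size could be small or large. The limit now covers more of this short series in this assay: the limit of > 500000 nM in this assay, at which 2 of the 4 values shown sit.

Going by these compounds, it remains open whether any other group on this ring nitrogen would give a number clearly under the limit, for example a longer chain ending in an amine or a carboxylic acid. On these data alone, the actual distance between compound 3 and compound 4 also stays unknown.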